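Chain extension at the ether oxygen and its expected effect

A few compounds are considered here, and "the series" means these few. Any claim that something is new, unique, unknown or untested is made for them only; others in the source may bear on it.

compound 1 `CCCCCOc1ccc(C(=O)c2cccc(Cn3ccnc3)c2)cc1`: 42 nM
compound 2 `CCCOc1ccc(C(=O)c2ccc(Cn3ccnc3)cc2)cc1`: 374 nM
compound 3 `C#CCOc1ccc(C(=O)c2cccc(Cn3ccnc3)c2)cc1`: 650 nM

In an assay on isolated protein for inhibition of Aromatase (Homo sapiens), read by fluorescence, with stated times of 10 min and 60 min (a higher number here means a weaker inhibitor, a lower number a stronger inhibitor), compound 2 gives 374 nM, the second highest of the three numbers; compound 3 lies within the scatter of it at 650 nM, while compound 1 lies well lower at 42 nM. Compound 4 `CCC#CCOc1ccc(C(=O)c2ccc(Cn3ccnc3)cc2)cc1` differs from compound 2 by but-1-yn-1-yl in place of ethyl on a saturated chain carbon bound to an oxygen on an aromatic ring. Going by the values given here, the one measured step on this chain is a 15-fold higher number from compound 1 to compound 3 (1.19 log units; beyond the scatter), which shortened the chain while introducing a triple bond; the change to compound 4 lengthens the chain while introducing one. A moderate lowering of the number is therefore expected for compound 4, a 1.9-fold lower number from compound 2 to compound 4 (0.27 log units; within the scatter), with wide uncertainty. Compound 4 is estimated at 200 nM, within 60 nM to 700 nM.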

Compound 4, half-maximal inhibitory concentration: 1430 nM
For compound 4 the middle estimate is 7.2-fold (0.85 log units) below the measured one, and the stated range ends below it.
By their numbers in this assay, from the lowest: compound 1; then compounds 2 and 3 (each within the scatter of the next); then compound 4.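

In this assay, replacing the propoxy chain with (pent-2-yn-1-yl)oxy gives a 3.8-fold higher number from compound 2 to compound 4 (0.58 log units; beyond the scatter), so at this position a longer chain carrying a triple bond does not lower the number. Alongside a 15-fold higher number from compound 1 to compound 3 (1.19 log units; beyond the scatter), both steps at this oxygen that bring in a triple bond raise the number, whether the chain becomes shorter or longer. Nothing available accounts for this rise.

The compounds shown leave open whether the triple bond or the added length drives the change in compound 4. They also leave open how a hexyl chain or an amine at this position would read.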